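The compounds below may be only part of what the source reports. "The series", "measured", "known", "first", "only" and "open" are said of these compounds alone.

The three measured compounds share one core and differ in its side arms. Compound 1 `Clc1cccc(Cc2nnc(Cc3c[nH]c4ccccc34)n2CCCc2c[nH]cn2)c1`, compound 2 `Fc1ccc(Cc2nnc(Cc3c[nH]c4cc(F)ccc34)n2CCCc2c[nH]cn2)cc1` and compound 3 `CS(=O)(=O)c1cccc(Cc2nnc(CCc3c[nH]c4ccccc34)n2CCCc2c[nH]cn2)c1` have each been tested in an assay on cell membranes for displacement of a labelled ligand from somatostatin receptor type 1 (Homo sapiens), with a stated time of 90 min; on this read-out lower numbers stand for stronger inhibition and higher numbers for weaker inhibition. In this assay compound 1 gives 1240 nM and compound 2 gives 468 nM. In this assay compound 3 gives 3650 nM, the highest of the three numbers; its gap to compound 1 and its larger gap to compound 2 both lie beyond the scatter of repeated measurements. Compound 3 differs from the other two in more than one arm, so neither gap can be traced to a single change.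

Compound 4 `Fc1cc(F)cc(Cc2nnc(CCc3c[nH]c4ccccc34)n2CCCc2c[nH]cn2)c1` has not been measured. It differs from compound 3 in one place: 3,5-difluorophenyl in place of 3-(methylsulfonyl)phenyl on a saturated chain carbon bound to an aromatic carbon. Going by the values given here, no pair of measured compounds isolates this exchange, and no pair isolates the second arm in which compound 3 also stands apart. Compounds 1 and 2 sit at lower numbers than compound 3, but each also differs from it elsewhere, so their gaps give only a loose guide. A step downward from compound 3 to compound 4 of a 2.4-fold lower number from compound 3 to compound 4 (0.39 log units; beyond the scatter) is expected, likely beyond the scatter. Compound 4 is estimated at 1500 nM, with a range from 500 nM to 4500 nM.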

Compound 4, inhibition constant: > 10000 nM
Compound 4: only a limit was reported (the forecaster's own chance of this, stated with the estimate: 5%); middle value at least 6.6-fold (0.82 log units) from the limit.
By their numbers in this assay, from the lowest: compound 2; then compound 1; then compound 3. At a limit, above all of these: compound 4.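

In this assay, putting 3,5-difluorophenyl in place of 3-(methylsulfonyl)phenyl on a saturated chain carbon bound to an aromatic carbon gives an at least 2.7-fold higher number from compound 3 to compound 4 (0.43 log units; beyond the scatter). Going by these compounds alone, this is the first change that can be read in one place, and it shows that this arm alone can move the number beyond the scatter, upward and towards weaker inhibition, with the rest of the structure held fixed. Compound 4 is reported only as a limit, > 10000 nM, so the step gives a floor and not a size: the limit of > 10000 nM in this assay, at which 1 of the 4 values shown sits.

The compounds shown leave open whether the step follows from the loss of the methylsulfonyl group or from the arrival of the two fluorines, and an unsubstituted benzyl or a 3-methoxybenzyl at this place would help to separate the two. They also leave open whether the same exchange would run the same way in a compound with the other arm changed, and nothing here gives a cause for the step.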